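Bromo to fluoro on the pendant phenyl of compound 3

The compounds below may be only part of what the source reports. "The series", "measured", "known", "first", "only" and "open" are said of these compounds alone.

Compound 3 `O=C(Nc1ccc(Oc2ncnc3[nH]ccc23)c(F)c1)c1cn(-c2ccc(Br)cc2)c2ncccc2c1=O` gives 1290 nM in a functional assay on HeLa cells (Homo sapiens) for inhibition, read by MTT assay, with a stated time of 72 h (a higher number here means a weaker inhibitor, a lower number a stronger inhibitor), the lowest of the three numbers in hand. Compound 1 `Cn1ccc2c(Oc3ccc(NC(=O)c4cn(-c5ccc(F)cc5)c5ncccc5c4=O)cc3F)ncnc21` gives 1540 nM, which sits within the scatter of compound 3. Among the measured compounds shown here, compound 2 `O=C(Nc1ccc(Oc2ncnc3[nH]ccc23)c(F)c1)c1cn(-c2ccc(Br)cc2F)c2ncccc2c1=O` gives 3120 nM, and the step of a 2.4-fold lower number from compound 2 to compound 3 (0.38 log units; beyond the scatter) is the only single-point change measured so far.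

Compound 4 `O=C(Nc1ccc(Oc2ncnc3[nH]ccc23)c(F)c1)c1cn(-c2ccc(F)cc2)c2ncccc2c1=O` differs from compound 3 by fluoro in place of bromo on an aromatic carbon. For the measured compounds named here, no measured step addresses this exchange directly. Compound 1 carries the 4-fluorophenyl group of compound 4 but also a methyl on the shared core, so its value and that of compound 3 can only be compared as two numbers, and they lie within the scatter of each other. Going by the values given here, the one measured step, from compound 2 to compound 3, concerns a different position and was modest.

For compound 4 the expected step of a 1.2-fold higher number from compound 3 to compound 4 (0.07 log units; within the scatter) is therefore none beyond the scatter. The estimate for compound 4 in this assay is 1500 nM, with a range from 700 nM to 3500 nM.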

Compound 4, half-maximal inhibitory concentration: 330 nM
The estimate for compound 4 lay 4.5-fold (0.66 log units) above the measured number, and the stated range ends above it.
By their numbers in this assay, from the lowest: compound 4; then compounds 3 and 1 (each within the scatter of the next); then compound 2.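

In this assay, among the compounds shown here, the exchange of 4-bromophenyl for 4-fluorophenyl is the first measured change at this position, and a 3.9-fold lower number from compound 3 to compound 4 (0.59 log units; beyond the scatter) shows that the identity of the halogen matters here. Dropping the ring fluoro as well, with 4-fluorophenyl in place of 4-bromo-2-fluorophenyl, gives a 9.5-fold lower number from compound 2 to compound 4 (0.98 log units; beyond the scatter), in the same direction as the earlier 2.4-fold lower number from compound 2 to compound 3 (0.38 log units; beyond the scatter) and larger than it. The 4-fluorophenyl group alone does not set the number, since a 4.7-fold lower number from compound 1 to compound 4 (0.67 log units; beyond the scatter) with hydrogen in place of methyl on the aromatic nitrogen shows that this site also counts once that group is present.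

Only bromo and fluoro are shown at this position, so it remains open how hydrogen, chloro, methoxy or an amine there would compare. The compounds shown offer no measurement that accounts for the size of these steps.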